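Swapping the group on the amide-type nitrogen of compound 3

This account rests on a few compounds, and the source may have more. Where it says the series, first, only, none or still open, it means among the compounds named here.

Compounds measured in a functional assay on PC-3 cells (Homo sapiens) for antiproliferative activity, read by MTT assay, with a stated time of 24 h (a higher number here means a weaker inhibitor, a lower number a stronger inhibitor), are these
- compound 1 `CCn1c(C(=O)NCCN)ccc1C(CC)(CC)c1ccc(OCS(=O)(=O)c2ccccc2)c(C)c1` gives 6890 nM
- compound 2 `CCN(CC)CCNC(=O)c1ccc(C(CC)(CC)c2ccc(OCS(=O)(=O)c3ccccc3)c(C)c2)n1CC` gives 7130 nM
- compound 3 `CCn1c(C(=O)NC(C)(C)CO)ccc1C(CC)(CC)c1ccc(OCS(=O)(=O)c2ccccc2)c(C)c1` gives 9850 nM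

In this assay compound 3 cannot be separated from the other two, and all three values lie within the scatter of one another. Compound 4 `CCn1c(C(=O)N[C@@H](CO)CCO)ccc1C(CC)(CC)c1ccc(OCS(=O)(=O)c2ccccc2)c(C)c1` keeps the shared core and carries 3-hydroxy-1-(hydroxymethyl)propyl in place of 1-(hydroxymethyl)-1-methylethyl on an amide-type nitrogen and has not yet been measured. Going by the values given here, three measured steps bear on this change, as each alters the group at that same nitrogen. They are a 1.4-fold higher number from compound 1 to compound 3 (0.16 log units; within the scatter) and a 1.4-fold higher number from compound 2 to compound 3 (0.14 log units; within the scatter) and a 1.0-fold higher number from compound 1 to compound 2 (0.01 log units; within the scatter) and none of them exceeds the scatter. On these steps alone, no shift beyond the scatter is expected in either direction. The estimated step is a 1.2-fold lower number from compound 3 to compound 4 (0.09 log units; within the scatter) and would remain within the scatter. Compound 4 is expected at 8000 nM in this assay with an estimated range from 4000 nM to 16000 nM for its measurement.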

Compound 4, half-maximal inhibitory concentration: 14100 nM
The estimate for compound 4 lay 1.8-fold (0.25 log units) below the measured number, within the range that was stated.
By their numbers in this assay, from the lowest: compounds 1, 2, 3 and 4 (each within the scatter of the next, the first and the last beyond it).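

In this assay, 3-hydroxy-1-(hydroxymethyl)propyl on the amide-type nitrogen stays within the scatter of 1-(hydroxymethyl)-1-methylethyl (a 1.4-fold higher number from compound 3 to compound 4 (0.16 log units; within the scatter)) and of 2-(diethylamino)ethyl (a 2.0-fold higher number from compound 2 to compound 4 (0.30 log units; within the scatter)). Against 2-aminoethyl it gives the first step at this nitrogen to pass the scatter, though only modestly (a 2.0-fold higher number from compound 1 to compound 4 (0.31 log units; beyond the scatter)), so the group here can shift the number, where the earlier steps showed no separation at all. No measurement at hand accounts for this shift.

The compounds shown leave open whether a carboxylic acid, a morpholine ring or a longer aminoalkyl chain on this nitrogen would move the number further in either direction. They also leave open how the opposite configuration of the stereocentre in 3-hydroxy-1-(hydroxymethyl)propyl would compare.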